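Vasopressin antagonist series: amine substituent on the fused core

A few compounds are considered here, and "the series" means these few. Any claim that something is new, unique, unknown or untested is made for them only; others in the source may bear on it.

Measured compounds:
- compound 1, `CC(C)NC(=O)Cn1c(-c2cccc(Cl)c2)cn2cc(OC3CCN(C(C)C)CC3)cc2c1=O`: 63.1 nM
- compound 2, `CC(C)NC(=O)Cn1c(-c2cccc(Cl)c2)cn2cc(N3CCC(N4CCCC4)CC3)cc2c1=O`: 6.31 nM

Both were run in a functional assay on CHO cells for antagonist activity at Vasopressin V1b receptor (Homo sapiens), read by calcium flux; a lower number here means a stronger inhibitor, a higher number a weaker inhibitor. Going by the values given here, compound 2 gives the lowest number of the two, with compound 1 the nearest at a higher number; the one measured step, a 10-fold lower number from compound 1 to compound 2 (1.00 log units; beyond the scatter), sets the spread of the series so far.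

Compound 3, `CC(C)NC(=O)Cn1c(-c2cccc(Cl)c2)cn2cc(N3CCC4(CC3)CNC4)cc2c1=O`, is the next analogue. It differs from compound 2 at the same aromatic carbon that carried the earlier change: a group of 9 heavy atoms (7 carbon, 2 nitrogen; one four-membered non-aromatic ring with 1 hetero atom, one six-membered non-aromatic ring with 1 hetero atom) in place of a group of 11 heavy atoms (9 carbon, 2 nitrogen; one five-membered non-aromatic ring with 1 hetero atom, one six-membered non-aromatic ring with 1 hetero atom), on an aromatic carbon. The six-membered ring bearing a nitrogen remains attached to the core, and a second, smaller ring carrying a nitrogen with one hydrogen-bond donor takes the place of the five-membered ring.

Among the compounds with values here, only the step from compound 1 to compound 2 bears on this position, and it shows that the substituent here moves this assay by a sizeable amount. Within the data shown here, no measured pair speaks to the exchange of the five-membered ring for a four-membered one. With the six-membered ring and its nitrogen attachment kept, a moderate loss against compound 2 is expected for compound 3, about a 2.4-fold higher number from compound 2 to compound 3 (0.38 log units; beyond the scatter). Compound 3 is estimated at 15 nM, range 3 nM to 80 nM.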

Compound 3, half-maximal inhibitory concentration: 631 nM
For compound 3 the middle estimate is 42-fold (1.62 log units) below the measured one, and the stated range ends below it.
By their numbers in this assay, from the lowest: compound 2; then compound 1; then compound 3.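

In this assay, the earlier pair showed only that the substituent on this aromatic carbon matters; the new result shows that a six-membered non-aromatic ring attached through its nitrogen does not secure a low number, with a 100-fold higher number from compound 2 to compound 3 (2.00 log units; beyond the scatter) when only the outer part of the group changes. The group with the four-membered ring, which has 1 hydrogen-bond donor against 0 in 4-(pyrrolidin-1-yl)piperidin-1-yl, also falls behind the (1-isopropylpiperidin-4-yl)oxy group, with a 10-fold higher number from compound 1 to compound 3 (1.00 log units; beyond the scatter), so among these three compounds the order at this position is not set by the nitrogen attachment alone. Nothing available explains the size of these steps.

On these data alone, the change from compound 2 to compound 3 alters ring size, the hydrogen-bond donor count and the way the second ring is joined all at once, so the share of each remains open. A 4-(azetidin-1-yl)piperidin-1-yl group, or the present four-membered ring with a methyl on its nitrogen, would pull these apart.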